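Benzyl for tert-butyl on the imidazole of compound 3

The compounds below may be only part of what the source reports. "The series", "measured", "known", "first", "only" and "open" are said of these compounds alone.

Three acids share one core. Compound 1 `O=C(O)c1ccccc1-c1ccc(CCc2ncc(CCC3CCCCC3)[nH]2)cc1` carries a 2-cyclohexylethyl group and gives 642 nM in an in vitro functional assay on cells for agonist activity at Bombesin receptor subtype-3 (Homo sapiens), read by luminescence and calcium flux; a lower number here means that less compound is needed, a higher number that more compound is needed for the effect. Compound 2 `O=C(O)c1ccccc1-c1ccc(CCc2ncc(Cc3cccc(Cl)c3)[nH]2)cc1` carries a 3-chlorobenzyl group and gives 825 nM. Compound 3 `CC(C)(C)c1cnc(CCc2ccc(-c3ccccc3C(=O)O)cc2)[nH]1` carries a tert-butyl group and gives 4330 nM, the highest of the three numbers; the gaps to compound 2 and to compound 1 are both beyond the scatter, so compound 3 needs the most compound for the effect.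

The next member, compound 4 `O=C(O)c1ccccc1-c1ccc(CCc2ncc(Cc3cccc(F)c3)[nH]2)cc1`, differs from compound 3 in one place: 3-fluorobenzyl in place of tert-butyl on an aromatic carbon.

Among the compounds with values here, two measured steps bear on this. The step of a 5.2-fold higher number from compound 2 to compound 3 (0.72 log units; beyond the scatter) shows that swapping a 3-chlorobenzyl group for tert-butyl on that aromatic carbon raised the number; the present change runs the other way, with fluorine in place of chlorine on the benzyl ring. The step of a 1.3-fold higher number from compound 1 to compound 2 (0.11 log units; within the scatter) shows that a cyclohexylmethyl and a 3-chlorophenyl group on the chain carbon sit within the scatter of each other, so the aryl group itself is tolerated. Within the data shown here, no step compares a fluorine with a chlorine on that ring. A drop of roughly the size of the reversed step, a 4.3-fold lower number from compound 3 to compound 4 (0.64 log units; beyond the scatter), is expected, with some allowance for the halogen swap. Compound 4 is estimated at 1000 nM, in the range 400 nM to 2500 nM, in this assay.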

Compound 4, half-maximal effective concentration: 159 nM
Beside the measured number, compound 4's estimate is 6.3-fold (0.80 log units) above it; the measured number lies below the stated range.
By their numbers in this assay, from the lowest: compound 4; then compounds 1 and 2 (each within the scatter of the next); then compound 3.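

Within the data shown here, the full step for this change, a 27-fold lower number from compound 3 to compound 4 (1.44 log units; beyond the scatter) in this assay, shows that a 3-fluorobenzyl group on this aromatic carbon gives far more than the earlier compounds could indicate. The halogen on the benzyl ring also matters here: a 5.2-fold lower number from compound 2 to compound 4 (0.72 log units; beyond the scatter) comes from fluoro in place of chloro alone, whereas compounds 1 and 2 had stayed within the scatter of each other. The group on this carbon therefore separates compound 4 from the 2-cyclohexylethyl compound as well, with a 4.0-fold lower number from compound 1 to compound 4 (0.61 log units; beyond the scatter) leaving compound 4 with the lowest number of the four, its steps to all the others being beyond the scatter.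

No measurement at hand accounts for the difference between the fluoro and chloro compounds.

Open, on these data alone, is how an unsubstituted benzyl or a 3-methoxybenzyl group would read on this carbon, which would set both halogen compounds against a ring without halogen. Also open, as far as these compounds go, is whether the gain from fluoro in place of chloro holds when a tetrazole or a primary amide replaces the carboxylic acid.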